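Replacing a methoxyphenyl with a chlorophenyl on the piperazine

This account rests on a few compounds, and the source may have more. Where it says the series, first, only, none or still open, it means among the compounds named here.

Measured so far:
- compound 1, `CCCc1nc(-c2ccccc2)c(CNCCN2CCN(c3ccc(Cl)cc3)CC2)o1`: 55.8%
- compound 2, `CCCc1nc(-c2ccccc2)c(CNCCCN2CCN(c3cccc(F)c3)CC2)o1`: 68.9%
- compound 3, `CCCc1nc(-c2ccccc2)c(CNCCCN2CCN(c3cccc(OC)c3)CC2)o1`: 36.4%

All three compounds share the same core and were tested in an assay on HEK293 cells for inhibition of Voltage-dependent T-type calcium channel subunit alpha-1G (Homo sapiens), read by fluorescence, tested at 10 uM; on this read-out higher numbers stand for more inhibition at the one concentration tested (going by the name of the read-out) and lower numbers for less inhibition. Compound 3 gives 36.4%, the lowest of the three numbers; compound 1 gives 55.8% and compound 2 gives 68.9%, both beyond the scatter above compound 3. The unmeasured compound 4, `CCCc1nc(-c2ccccc2)c(CNCCCN2CCN(c3ccccc3Cl)CC2)o1`, differs from compound 3 in one place: 2-chlorophenyl in place of 3-methoxyphenyl on an amine nitrogen in a ring.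

For the measured compounds named here, the one measured step that touches this position is a number 32.5 percentage points lower from compound 2 to compound 3 (beyond the scatter). Going by the values given here, the group that leaves compound 3 is the same methoxyphenyl that entered there, so removing it is expected to recover much of what was lost, though the halogen now sits on a different ring carbon and no measured step tells how that matters. Compound 1, carrying a chlorophenyl on a shorter chain, gives 55.8%, which supports an upward expectation.

Compound 4 is therefore expected to show a rise of about a number 19.6 percentage points higher from compound 3 to compound 4 (beyond the scatter), landing near 56% with a range from 36% to 74%.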

Compound 4, a percentage reported as inhibition, at one concentration (the size of the read-out at that concentration, not a potency): 64.7%
For compound 4 the middle estimate is 8.7 percentage points below the measured one; the measured number falls inside the stated range.
By their numbers in this assay, from the lowest: compound 3; then compounds 1, 4 and 2 (each within the scatter of the next, the first and the last beyond it).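

In this assay, 2-chlorophenyl in place of 3-methoxyphenyl on the amine nitrogen in the ring gives a number 28.3 percentage points higher from compound 3 to compound 4 (beyond the scatter), the reverse direction of a number 32.5 percentage points lower from compound 2 to compound 3 (beyond the scatter). Compound 3 is therefore separated from both halogen-bearing compounds, whereas 2-chlorophenyl in place of 3-fluorophenyl gives a number 4.2 percentage points lower from compound 2 to compound 4 (within the scatter), so these two groups cannot be told apart here even though the halogen and its ring carbon both differ. Nothing available explains why 3-methoxyphenyl gives the different result.

The role of the ring carbon and that of the group itself remain tangled, and 2-methoxyphenyl and 3-chlorophenyl on the same nitrogen would help separate them. An unsubstituted phenyl there would show whether either kind of group is needed at all.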